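Moving the carboxylic acid around the phenyl ring

A few compounds are considered here, and "the series" means these few. Any claim that something is new, unique, unknown or untested is made for them only; others in the source may bear on it.

Measured so far:
compound 1 `O=C(N[C@H]1CC[C@H](C(=O)O)CC1)[C@H](C1CCCCC1)n1c(-c2ccc(Cl)nc2)nc2cc(F)c(F)cc21`, 1700 nM
compound 2 `COc1ccc(-c2nc3cc(F)c(F)cc3n2[C@H](C(=O)N[C@H]2CC[C@H](C(=O)O)CC2)C2CCCCC2)c(Cl)n1`, 290 nM
compound 3 `O=C(O)c1ccccc1NC(=O)C(C1CCCCC1)n1c(-c2ccc(Cl)cc2)nc2cc(F)c(F)cc21`, 320 nM

In an assay on isolated protein for displacement of a labelled ligand from Bile acid receptor (Homo sapiens), read by scintillation proximity assay and radioligand binding (a higher number here means a weaker inhibitor, a lower number a stronger inhibitor), compound 3 gives 320 nM, the second highest of the three numbers; compound 2 gives 290 nM, within the scatter of it, while compound 1 gives 1700 nM, well beyond. Compound 4 `O=C(O)c1cccc(NC(=O)C(C2CCCCC2)n2c(-c3ccc(Cl)cc3)nc3cc(F)c(F)cc32)c1` differs from compound 3 by 3-carboxyphenyl in place of 2-carboxyphenyl on an amide-type nitrogen. For the measured compounds named here, the only measured step, a 5.9-fold lower number from compound 1 to compound 2 (0.77 log units; beyond the scatter), concerns a different part of the shared core and does not bear on this change. Going by the values given here, with no comparable pair, compound 4 is estimated near compound 3, with a step of a 1.9-fold higher number from compound 3 to compound 4 (0.27 log units; within the scatter) expected. Compound 4 is therefore expected to give about 600 nM, between 150 nM and 2500 nM.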

Compound 4, half-maximal inhibitory concentration: 1300 nM
Compound 4: the middle estimate sits 2.2-fold (0.34 log units) below what was measured; the range from low to high includes it.
By their numbers in this assay, from the lowest: compounds 2 and 3 (each within the scatter of the next); then compounds 4 and 1 (each within the scatter of the next).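

In this assay, 3-carboxyphenyl in place of 2-carboxyphenyl on the amide-type nitrogen gives a 4.1-fold higher number from compound 3 to compound 4 (0.61 log units; beyond the scatter) with no change in the atoms present, only in how they are joined. For the compounds shown here, this is the first measured step at this position, and it shows that where the carboxylic acid sits on the phenyl ring affects the number, with compound 3 the stronger. Nothing available explains this difference. Still open, as far as these compounds go, is whether a tetrazole or a carboxymethyl group in place of the carboxylic acid would match compound 3 or compound 4.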